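The source may report more compounds than this note shows. Statements on the series, on what has been measured and on what is new or still open speak of the compounds shown alone.

Of the compounds shown here, two of the shared core have so far been measured in an in vitro functional assay on HEK285-7 cells for antagonist activity at prostaglandin D2 receptor 2 (Homo sapiens), read by BRET and beta-arrestin recruitment; a higher number here means a larger maximal response, a lower number a smaller maximal response. Compound 1, `O=C(O)Cc1sc(C(c2ccc(F)cc2)c2ccc(F)cc2)nc1-c1ccnc(F)c1`, reaches 80% in this assay, and this is the higher of the two numbers at hand. Compound 2, `O=C(O)Cc1sc(C(Cc2ccccc2)c2ccccc2)nc1-c1ccc(Cl)cc1`, gives 50% in this assay, a gap that lies beyond the usual scatter of such measurements. Compound 2 differs from compound 1 in several places at once, so the two values only show that the pair sits apart, and nothing more can be drawn from them about any single change.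

Compound 3, `N#Cc1cc(-c2nc(C(c3ccc(F)cc3)c3ccc(F)cc3)sc2CC(=O)O)ccc1F`, has not yet been measured. It differs from compound 1 in one place: 3-cyano-4-fluorophenyl in place of 2-fluoropyridin-4-yl on an aromatic carbon. Going by the values given here, no pair of measured compounds isolates this exchange, so there is no measured step to lean on, and the size of the expected step rests on the change alone. One aromatic ring is traded for another at the same place on the core, the acid-bearing chain and the large group remaining untouched. Compound 3 is therefore expected to reach about 75% in this assay, with a range from 55% to 95%. That estimate means a step of a number 5 percentage points lower from compound 1 to compound 3 (within the scatter), which is expected to stay within the usual scatter rather than beyond it.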

Compound 3, largest response reached (reported as efficacy), in percent of the reference or control that the assay uses: 80%
The estimate for compound 3 lay 5 percentage points below the measured number; low and high end bracket the measured number.
By their numbers in this assay, from the lowest: compound 2; then compounds 1 and 3 (each within the scatter of the next).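

In this assay, going by these compounds alone, the exchange of 2-fluoropyridin-4-yl for 3-cyano-4-fluorophenyl on the aromatic carbon next to the ring nitrogen brings no change at the digits printed from compound 1 to compound 3 (within the scatter) and so gives the first reading of a change at one place on the shared core. Within the data shown here, for this pair, with the carboxymethyl group and the large group untouched, a six-membered aromatic ring with a hetero atom and a six-membered aromatic ring of carbon only that carries a cyano group can replace each other at this position without a shift in maximal response beyond the scatter. No measurement at hand says why the two rings read alike.

The compounds shown leave open whether the cyano group and the fluorine on the new ring matter separately, and whether a plain phenyl, an aminopyridine or a ring bearing a morpholine would read the same at this position. Compound 2 differs from compound 1 and compound 3 in several places, so steps to it cannot be read, and the part played by the large group remains unresolved.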